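The source may report more compounds than this note shows. Statements on the series, on what has been measured and on what is new or still open speak of the compounds shown alone.

In a functional assay on PC-3 cells (Homo sapiens) for inhibition, read by MTT assay, with a stated time of 48 h; on this read-out lower numbers stand for stronger inhibition and higher numbers for weaker inhibition:
- compound 1 `COc1ccc(-n2c(SCc3ccc(F)cc3)nnc2-c2cc(OC)c(OC)c(OC)c2)cc1`: 35000 nM
- compound 2 `CCOC(=O)CSc1nnc(-c2cc(OC)c(OC)c(OC)c2)n1-c1ccc(OC)cc1`: > 60000 nM (a limit)
- compound 3 `COc1cc(-c2nnc(SCc3ccc(F)cc3)n2-c2ccc(N(C)C)cc2)cc(OC)c1OC`: 46500 nM

Compound 3 lies within the scatter of compound 1, and the only other result is a limit.

Next is compound 4 `CCOC(=O)CSc1nnc(-c2cc(OC)c(OC)c(OC)c2)n1-c1ccc(N(C)C)cc1`, not yet measured, with this change: ethoxycarbonyl in place of 4-fluorophenyl on a saturated chain carbon bound to a sulfur. Ethoxycarbonyl replaces 4-fluorophenyl on a saturated chain carbon bound to a sulfur.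

The same exchange on the methoxy compound gave an at least 1.7-fold higher number from compound 1 to compound 2 (0.23 log units; that floor lies within the scatter). Replacing methoxy with dimethylamino gave a 1.3-fold higher number from compound 1 to compound 3 (0.12 log units; within the scatter), so the first step is expected to carry over: a small rise in this assay, possibly no more than scatter.

The expected step is a 1.6-fold higher number from compound 3 to compound 4 (0.21 log units; within the scatter). A limit rather than a number is also likely.

Compound 4 is estimated at 75000 nM, with an expected range of 42000 nM to 140000 nM.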

Compound 4, half-maximal inhibitory concentration: > 60000 nM
Compound 4 gave a limit, no number; the forecaster's own chance of this, stated with the estimate: 60%; the middle value is on the limit's open side.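

In this assay, ethoxycarbonyl in place of 4-fluorophenyl on a saturated chain carbon bound to a sulfur now also reads on the dimethylamino compound, giving an at least 1.2-fold higher number from compound 3 to compound 4 (0.11 log units; that floor lies within the scatter). Compound 4 gives only a limit, > 60000 nM, and ethoxycarbonyl now ends in a limit on both cores: the limit of > 60000 nM in this assay, at which 2 of the 4 values shown sit. The exchange can therefore be compared on two cores only as far as the limits allow: the same change on two cores in this assay, an at least 1.7-fold higher number (0.23 log units; that floor lies within the scatter) from compound 1 to compound 2 and an at least 1.2-fold higher number (0.11 log units; that floor lies within the scatter) from compound 3 to compound 4; the limit leaves it open whether they differ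

The step from compound 2 to compound 4 cannot be read, as both results are limits. On these data alone, the true size of the exchange on either core stays open, as does the outcome with a carboxylic acid or a longer chain at this position.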